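Cyanoacrylate esters in the writhing test: the ethyl ester

The compounds below may be only part of what the source reports. "The series", "measured", "known", "first", "only" and "open" are said of these compounds alone.

Measured so far in a functional assay on the whole organism (strain CD-1) for inhibition, with Mus musculus as the target, in the writhing test, with stated times of 15 min and 20 min, at a dose of 10 mg/kg by the subcutaneous route; on this read-out lower numbers stand for less inhibition and higher numbers for more inhibition at the one dose given (going by the name of the read-out):
compound 1, `Cc1ccc(/C=C(\C#N)C(=O)OC/C=C/c2ccccc2)cc1C`, gives 18.4%
compound 2, `CC(=O)Oc1ccc(/C=C(\C#N)C(=O)OC/C=C/c2ccccc2)cc1OC(C)=O`, gives 29%
compound 3, `N#C/C(=C\c1ccc(O)c(O)c1)C(=O)OCC#Cc1ccccc1`, gives 22%

All three numbers sit close together. Compound 3 falls in the middle of the three, and its gaps to compound 1 and to compound 2 both lie within the usual scatter of this assay, so no ordering among the measured compounds can be read from these numbers. Among the compounds with values here, no pair of measured compounds differs in only one place, so no step between them is available to lean on.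

Compound 4, `CCOC(=O)/C(C#N)=C/c1ccc(O)c(O)c1`, is not yet measured. It differs from compound 3 in one place: methyl in place of 2-phenylethynyl on a saturated chain carbon bound to an oxygen next to a carbonyl group. The catechol-bearing part of the shared core is kept unchanged, and only the ester side is shortened.

Within the data shown here, with no comparable single step among the measured compounds, the expected step in this assay from compound 3 to compound 4 is put at none beyond the scatter, with the direction left open. Compound 4 is therefore expected to give about 20% in this assay, within a range of 5% to 38%, which would mean a step of a number 2 percentage points lower from compound 3 to compound 4 (within the scatter) from compound 3.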

Compound 4, a percentage reported as inhibition, in the whole organism at one dose (the size of the read-out at that dose, not a potency): 21.8%
Compound 4: the middle estimate sits 1.8 percentage points below what was measured; low and high end bracket the measured number.
By their numbers in this assay, from the lowest: compounds 1, 4, 3 and 2 (each within the scatter of the next, the first and the last beyond it).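

In this assay the series gains its first comparison in one place, a number 0.2 percentage points lower from compound 3 to compound 4 (within the scatter), with methyl in place of 2-phenylethynyl on a saturated chain carbon bound to an oxygen next to a carbonyl group. At this position, in this pair, the exchange removes the six-membered aromatic ring and the triple bond together without any step beyond the scatter, so the read-out at this one dose does not depend on either of them here. Nothing available explains why this change leaves the number in place, and no measurement bears on it.

Still open, going by these compounds, is whether a longer chain, a carboxylic acid or an amine at this position would move the number beyond the scatter, and whether the same exchange would behave alike with the other substitution patterns of compound 1 and compound 2. On these data alone, the read-out is a size at a single dose and not a potency, so whether compound 3 and compound 4 would also stay together at other doses remains open.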